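The compounds below may be only part of what the source reports. "The series", "measured", "known", "first", "only" and "open" are said of these compounds alone.

Of the compounds shown here, two sharing one core have been measured so far. In a functional assay on CHO cells with adenosine receptor A1 (Homo sapiens) as the target, read by cAMP accumulation and immunoassay, with a stated time of 6 min, tested at 0.1 uM (a lower number here means a stronger effect, a higher number a weaker effect of the compound at the concentration tested), compound 1 `Nc1scc(CN2CCN(c3cccc(Cl)c3Cl)CC2)c1C(=O)c1ccc(Cl)cc1` gives 3.2%, and compound 2 `Nc1scc(CN2CCN(c3cc(Cl)cc(Cl)c3)CC2)c1C(=O)c1ccc(Cl)cc1` gives -22%, the lowest of the two numbers. Among the compounds with values here, the only step between them is a number 25.2 percentage points lower from compound 1 to compound 2 (beyond the scatter). The next compound, compound 3 `Nc1scc(CN2CCN(c3ccc(Cl)c(C(F)(F)F)c3)CC2)c1C(=O)c1ccc(Cl)cc1`, differs from compound 2 in one place: 4-chloro-3-(trifluoromethyl)phenyl in place of 3,5-dichlorophenyl on an amine nitrogen in a ring. Within the data shown here, no measured step puts 4-chloro-3-(trifluoromethyl)phenyl in place of anything, so the single known step is the only guide, and it bears on this change only loosely: it shows that moving the chlorines around the same phenyl ring shifted the read-out beyond the scatter, so a change on this ring may again move the number, while the direction stays open. Because compound 2 sits at -22%, a drift back toward the number of compound 1 seems at least as plausible as a further fall. Compound 3 is therefore expected at -5%, within -30% to 20%. That estimate means an expected step of a number 17 percentage points higher from compound 2 to compound 3 (beyond the scatter), which may or may not exceed the scatter.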

Compound 3, a percentage reported as activity, at one concentration (the size of the read-out at that concentration, not a potency): -12%
Compound 3: the middle estimate sits 7 percentage points above what was measured, within the range that was stated.
By their numbers in this assay, from the lowest: compounds 2 and 3 (each within the scatter of the next); then compound 1.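

Replacing 3,5-dichlorophenyl with 4-chloro-3-(trifluoromethyl)phenyl on the amine nitrogen gives a number 10 percentage points higher from compound 2 to compound 3 (within the scatter) in this assay, so this larger group, with trifluoromethyl in place of one chlorine, leaves compound 3 indistinguishable from compound 2. Compared with the 2,3-dichlorophenyl group, the same change gives a number 15.2 percentage points lower from compound 1 to compound 3 (beyond the scatter), so two differently substituted phenyl groups now both read lower than compound 1, which is the one compound of the three that stands apart. Nothing measured here explains why the read-out follows the groups in this way.

As far as these compounds go, all three compounds carry chlorine on this phenyl ring, so it remains open how the read-out would respond to a methoxy group, a nitrile or an amine on the ring, or to a plain phenyl ring with no added group at all. Each number also comes from a single concentration, which shows the size of the effect at that concentration but leaves open how the potencies of these compounds compare.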